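A few compounds are considered here, and "the series" means these few. Any claim that something is new, unique, unknown or untested is made for them only; others in the source may bear on it.

In a functional assay on SH-SY5Y cells (Homo sapiens) for antiproliferative activity, read by MTT assay, with a stated time of 72 h (on this read-out higher numbers stand for weaker inhibition and lower numbers for stronger inhibition), compound 3, `COc1cc2c(Nc3ccc(C#N)cc3)ncnc2cc1OCCCN1CCc2ccccc2C1`, gives only a limit of the assay, > 100000 nM, and no number. Compound 1, `CCN(CC)CCCOc1cc2ncnc(Nc3ccc(C#N)cc3)c2cc1OC`, likewise reaches only a limit, > 100000 nM. Both sit at the limit of > 100000 nM in this assay, at which 2 of the 3 values shown sit. Going by the values given here, compound 2, `COc1cc2c(Nc3ccc(C#N)cc3)ncnc2cc1OCCCN1CCC(c2ccccc2)CC1`, is the one compound here with a measured number, 7770 nM, in this assay.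

Compound 4, `COc1cc2c(Nc3ccc(C#N)cc3)ncnc2cc1OCCCN1CCN(c2ccncc2)CC1`, is not yet measured. It differs from compound 3 by 4-(pyridin-4-yl)piperazin-1-yl in place of 1,2,3,4-tetrahydroisoquinolin-2-yl on a saturated chain carbon, three bonds along the chain from an oxygen on an aromatic ring. Among the compounds with values here, two measured steps bear on this change. Moving from a diethylamino group to the 4-phenylpiperidinyl group gave an at least 12-fold lower number from compound 1 to compound 2 (1.10 log units; beyond the scatter). Going on from that group to the tetrahydroisoquinolinyl group gave an at least 12-fold higher number from compound 2 to compound 3 (1.10 log units; beyond the scatter). The step from compound 1 to compound 3 cannot be read, as both values are limits. Compound 4 carries, like compound 2, a six-membered aromatic ring on a six-membered saturated ring bearing the chain nitrogen, so a number nearer that of compound 2 than the limit of compound 3 is expected; since compound 3 stands at a limit, the size of the expected step of an at least 5.0-fold lower number from compound 3 to compound 4 (0.69 log units; beyond the scatter) is uncertain. For compound 4 in this assay the estimate is 20000 nM, with a likely range from 4000 nM to 100000 nM.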

Compound 4, half-maximal inhibitory concentration: 31600 nM
Estimate against measurement, compound 4: 1.6-fold (0.20 log units) below; low and high end bracket the measured number.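

In this assay, the 4-(pyridin-4-yl)piperazin-1-yl group gives the second measured number in this set, so a measurable result at this chain position no longer rests on the 4-phenylpiperidin-1-yl group of compound 2 alone: replacing the 1,2,3,4-tetrahydroisoquinolin-2-yl group gives an at least 3.1-fold lower number from compound 3 to compound 4 (0.50 log units; beyond the scatter), and replacing diethylamino gives an at least 3.1-fold lower number from compound 1 to compound 4 (0.50 log units; beyond the scatter). The new group does not match the 4-phenylpiperidin-1-yl group, however, as the change between these two gives a 4.1-fold higher number from compound 2 to compound 4 (0.61 log units; beyond the scatter), so the position responds to differences between two groups that each carry a six-membered aromatic ring on a six-membered saturated ring. The steps from compound 1 and compound 3 give only a minimum size, since both of those compounds stand at a limit and not at a number: the limit of > 100000 nM in this assay, at which 2 of the 4 values shown sit.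

The swap from compound 2 to compound 4 alters both rings of the group at once, so the compounds shown leave open which ring accounts for the step, a question that a 4-phenylpiperazin-1-yl group on the same chain could help to settle. Also open, on these data alone, is whether a longer chain would change how these groups rank.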